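The source may report more compounds than this note shows. Statements on the series, on what has been measured and on what is new or still open speak of the compounds shown alone.

The shared core of compound 3 `Cn1cc(S(=O)(=O)Nc2ccc(Cc3nc4c([nH]3)c(=O)n(Cc3ccccc3F)c(=O)n4CC3CC3)cc2)cn1` carries a sulfonamide whose sulfur bears a small five-membered heteroaryl group, and in an assay on isolated protein for inhibition of phosphoenolpyruvate carboxykinase, cytosolic [GTP] (Homo sapiens) (a higher number here means a weaker inhibitor, a lower number a stronger inhibitor), compound 3 gives 390 nM. Its two neighbours in this series are compound 1 `Cc1nc(S(=O)(=O)Nc2ccc(Cc3nc4c([nH]3)c(=O)n(Cc3ccccc3F)c(=O)n4CC3CC3)cc2)cn1C`, which gives 340 nM, and compound 2 `Cc1nc(N)sc1S(=O)(=O)Nc1ccc(Cc2nc3c([nH]2)c(=O)n(Cc2ccccc2F)c(=O)n3CC2CC2)cc1`, which gives 230 nM. Both comparisons stay inside the scatter: a 1.1-fold higher number from compound 1 to compound 3 (0.06 log units; within the scatter) and a 1.7-fold higher number from compound 2 to compound 3 (0.23 log units; within the scatter), so compound 3 stands level with the others on the numbers shown.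

Compound 4 `Cc1noc(C)c1S(=O)(=O)Nc1ccc(Cc2nc3c([nH]2)c(=O)n(Cc2ccccc2F)c(=O)n3CC2CC2)cc1` differs from compound 3 by one change, (3,5-dimethyl-1,2-oxazol-4-yl in place of 1-methyl-1H-pyrazol-4-yl on a sulfonyl sulfur). The three measured steps that bear on it all swap one heteroaryl for another on the same sulfonyl sulfur: a 1.5-fold lower number from compound 1 to compound 2 (0.17 log units; within the scatter), a 1.1-fold higher number from compound 1 to compound 3 (0.06 log units; within the scatter) and a 1.7-fold higher number from compound 2 to compound 3 (0.23 log units; within the scatter). None of these exchanges moved this assay beyond the scatter. On that basis a further exchange of the same kind is expected to produce no step beyond the scatter either, that is an expected 1.1-fold lower number from compound 3 to compound 4 (0.05 log units; within the scatter). The value for compound 4 is therefore estimated at 350 nM, with a range from 150 nM to 800 nM.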

Compound 4, half-maximal inhibitory concentration: 790 nM
For compound 4 the middle estimate is 2.3-fold (0.35 log units) below the measured one, and the stated range covers the measured number.
By their numbers in this assay, from the lowest: compounds 2, 1 and 3 (each within the scatter of the next); then compound 4.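

Among the compounds shown here, the position on the sulfonyl sulfur proves not to be indifferent to the heteroaryl it carries in this assay, since 3,5-dimethyl-1,2-oxazol-4-yl gives the first steps beyond the scatter (a 2.0-fold higher number from compound 3 to compound 4 (0.31 log units; beyond the scatter)) (a 2.3-fold higher number from compound 1 to compound 4 (0.37 log units; beyond the scatter)) (a 3.4-fold higher number from compound 2 to compound 4 (0.54 log units; beyond the scatter)). All three steps are modest and run the same way, so this group alone separates from the other three, which stay level with one another. Nothing shown here gives a reason for this change.

The compounds shown leave open whether the step follows the ring oxygen, the two methyl groups or the two together, which a 3,5-dimethyl-1H-pyrazol-4-yl group on the same sulfur would help to separate. They also leave open how a plain phenyl or a small alkyl chain would read at this position.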